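Working notes on two measured compounds and one pending

The source may report more compounds than this note shows. Statements on the series, on what has been measured and on what is new or still open speak of the compounds shown alone.

Of the compounds shown here, two sharing one core have been measured in a functional assay, with a stated time of 150 min; a lower number here means a stronger inhibitor, a higher number a weaker inhibitor. Compound 1, `CSc1nc(-c2ccco2)c(C#N)c(=O)n1C`, gives 108 ug/mL. Compound 2, `CCOC(=O)c1cnn(-c2nc(-c3ccc(OC)cc3)c(C#N)c(=O)n2C)c1N`, gives 79 ug/mL in this assay. Among the measured compounds shown here, compound 2 has the lowest of the two numbers so far, but its only neighbour is compound 1, and the gap between them lies within the scatter of repeated measurements, so the two are not distinguishable on the present data. Both numbers sit at the weak end of what the read-out usually reports.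

Compound 3, `CCOC(=O)c1cnn(-c2nc(-c3cccc(O)c3O)c(C#N)c(=O)n2C)c1N`, is the next compound to be measured. Its relation to compound 2 is a single change on one aromatic carbon: 2,3-dihydroxyphenyl in place of 4-methoxyphenyl on an aromatic carbon.

For the measured compounds named here, no step between measured compounds is available, so nothing itself shows how this kind of exchange moves the read-out. The expectation for compound 3 rests on compound 2 alone, whose value 79 ug/mL anchors the estimate, and the step expected is a 1.0-fold higher number from compound 2 to compound 3 (0.01 log units; within the scatter), that is, no change beyond the scatter in either direction. For compound 3 the estimated value in this assay is 80 ug/mL, with a range from 35 ug/mL to 180 ug/mL.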

Compound 3, half-maximal inhibitory concentration: 58 ug/mL
Compound 3: middle estimate off by 1.4-fold (0.14 log units), on the high side; measured number inside the range.
By their numbers in this assay, from the lowest: compounds 3, 2 and 1 (each within the scatter of the next).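

This result gives the series its first step at this position, the aromatic carbon ortho to a cyano group and next to the ring nitrogen. In this assay the exchange of 4-methoxyphenyl for 2,3-dihydroxyphenyl gives a 1.4-fold lower number from compound 2 to compound 3 (0.13 log units; within the scatter) and so does not separate the two groups, even though the entering group carries 2 hydrogen-bond donors and the leaving group 0. The compounds shown therefore give no sign that this substituent pattern on the aryl ring governs the read-out, at least for this pair, and nothing available explains the result or says what lies behind the small gap.

One step between two substituted phenyl groups cannot show how far the read-out can move at this carbon, and the series still holds no change here that lies beyond the scatter. Open questions are whether a phenyl ring bearing an amine or a carboxylic acid, or a longer alkyl chain in place of the aryl ring, would shift the number clearly, and whether either hydroxyl group alone would behave as the pair does.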